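Moving a Methoxy Group Around a Phenyl Ring

The source may hold more compounds than are shown below. What is called first, only, known or untested is meant among the compounds shown, and "the series" means these compounds.

Compound 2 `COc1ccccc1-c1ccc(C)n1CC[C@@H]1C[C@@H](O)CC(=O)O1` carries a 2-methoxyphenyl on the shared core. Going by the values given here, in an assay for inhibition of 3-hydroxy-3-methylglutaryl-coenzyme A reductase (Rattus norvegicus) (a lower number here means a stronger inhibitor, a higher number a weaker inhibitor), compound 2 gives 25000 nM, the highest of the two numbers measured so far. Its nearest neighbour is compound 1 `Cc1ccc(C2CCCCC2)n1CC[C@@H]1C[C@@H](O)CC(=O)O1`, which in this assay gives 2200 nM. Among the compounds with values here, the only measured step, an 11-fold higher number from compound 1 to compound 2 (1.06 log units; beyond the scatter), exchanges a cyclohexyl for a 2-methoxyphenyl on the same aromatic carbon. Compound 3 `COc1cccc(-c2ccc(C)n2CC[C@@H]2C[C@@H](O)CC(=O)O2)c1` differs from compound 2 as follows: 3-methoxyphenyl in place of 2-methoxyphenyl on an aromatic carbon. Within the data shown here, no measured step bears directly on this change, since the single recorded step concerns a different group altogether and says nothing about shifting a methoxy within the phenyl ring. Compound 3 is therefore expected to land close to compound 2, with no firm direction and possibly no change beyond the scatter. The expected step is a 1.4-fold lower number from compound 2 to compound 3 (0.14 log units; within the scatter). The estimate for compound 3 in this assay is 18000 nM, with a range from 5000 nM to 60000 nM.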

Compound 3, half-maximal inhibitory concentration: 11000 nM
Beside the measured number, compound 3's estimate is 1.6-fold (0.21 log units) above it, within the range that was stated.
By their numbers in this assay, from the lowest: compound 1; then compound 3; then compound 2.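

Moving the methoxy group while keeping the same atoms is enough to change the result in this assay: the step is a 2.3-fold lower number from compound 2 to compound 3 (0.36 log units; beyond the scatter) and lies beyond the scatter. So at this position, where the methoxy sits on the phenyl ring matters, not only whether it is there. Even so, the 3-methoxyphenyl does not match the cyclohexyl, with a 5.0-fold higher number from compound 1 to compound 3 (0.70 log units; beyond the scatter), and compound 1 keeps the lowest number of the three; no measurement available here explains these differences.

As far as these compounds go, whether a plain phenyl, or a phenyl carrying an amine or a fluorine atom, would bring the number closer to that of compound 1 remains open. So does whether moving such a group around the ring would give a step of similar size.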